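A methyl swap among compounds held at a limit

This account rests on a few compounds, and the source may have more. Where it says the series, first, only, none or still open, it means among the compounds named here.

In a functional assay on NCI-H460 cells (Homo sapiens) for cytotoxicity, read by MTT assay, with a stated time of 24 h (a lower number here means a stronger inhibitor, a higher number a weaker inhibitor), compound 1 `C#CCn1c(=O)c(C=O)cc2cc(Cl)ccc21` reads > 100000 nM as a limit of the assay and not as a number. Compound 2 `C#CCn1c(=O)c(C=O)cc2cc(F)ccc21` reads > 100000 nM and that too is a limit. Compound 3 `C#CCn1c(=O)c(C=O)cc2cc(OC)ccc21` reads > 100000 nM and this is again only a limit. It therefore has no number of its own and shares the limit of > 100000 nM in this assay, at which 3 of the 3 values shown sit, with the other two.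

Compound 4 `C#CCn1c(=O)c(C=O)cc2cc(C)ccc21` carries methyl in place of methoxy on an aromatic carbon and is otherwise the same as compound 3. Three measured steps exchange the group at that same place, and they offer no size: a step that the two limits leave unreadable from compound 1 to compound 2 and a step that the two limits leave unreadable from compound 1 to compound 3 and a step that the two limits leave unreadable from compound 2 to compound 3 are all unreadable. On those steps, no change beyond the scatter is expected in this assay in either direction. The expected step is a step that the limit leaves unreadable from compound 3 to compound 4 and this is an estimate only. For compound 4 the estimated value is 150000 nM with a range from 70000 nM to 350000 nM and the assay may well report only a limit.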

Compound 4, half-maximal inhibitory concentration: > 100000 nM
Compound 4 was reported as a limit; the forecaster's own chance of this, stated with the estimate: 85%; the middle value does not contradict the limit.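

Compound 4, like compound 1, compound 2 and compound 3, gives no number in this assay, so no step among them can be read, and all four stand at one limit: the limit of > 100000 nM in this assay, at which 4 of the 4 values shown sit.

The compounds shown leave open whether exchanging the group at this place on the shared core changes the read-out at all.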